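Ring size on the amide carbonyl and enzyme inhibition

The source may report more compounds than this note shows. Statements on the series, on what has been measured and on what is new or still open speak of the compounds shown alone.

Measured in a functional assay for inhibition of kynurenine 3-monooxygenase (Rattus norvegicus), tested at 1 mM; a lower number here means less inhibition, a higher number more inhibition at the concentration tested (going by the name of the read-out):
compound 1 `COc1ccc(N)c(C(=O)CCNC(=O)C2CCC2)c1` gives 92.2%
compound 2 `COc1ccc(N)c(C(=O)CCNC(=O)C2CC2)c1` gives 99.9%

Compound 2 gives the higher of the two numbers shown, yet the only step between measured compounds, a number 7.7 percentage points higher from compound 1 to compound 2 (within the scatter), lies within the scatter, so the two compounds cannot be told apart on this read-out. Both numbers are high and level with each other at the concentration tested.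

Compound 3 `COc1ccc(N)c(C(=O)CCNC(=O)C2CCCCC2)c1` differs from compound 2 in one place: cyclohexyl in place of cyclopropyl on a carbonyl carbon. The step that bears on this change is a number 7.7 percentage points higher from compound 1 to compound 2 (within the scatter), which also swapped one small carbon ring for another on the same carbonyl carbon and produced no shift beyond the scatter. The new ring is larger than either of those, which adds some uncertainty, but with nothing pointing to a loss, the step of a number 9.9 percentage points lower from compound 2 to compound 3 (within the scatter) is expected to stay within the scatter. Compound 3 is therefore estimated at 90%, with a range from 65% to 100%.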

Compound 3, a percentage reported as inhibition, at one concentration (the size of the read-out at that concentration, not a potency): 99.6%
For compound 3 the middle estimate is 9.6 percentage points below the measured one; the measured number falls inside the stated range.
By their numbers in this assay, from the lowest: compounds 1, 3 and 2 (each within the scatter of the next).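

Cyclohexyl on this carbonyl carbon, whose other neighbour is an amide-type nitrogen, holds up as well as cyclopropyl in this assay, with a number 0.3 percentage points lower from compound 2 to compound 3 (within the scatter). It also cannot be told apart from cyclobutyl, with a number 7.4 percentage points higher from compound 1 to compound 3 (within the scatter). Within the data shown here, the earlier pair covered only two small rings, whereas these steps extend the comparison to a ring of 6 heavy atoms, and no difference among the three carbon rings can be read at this concentration. Nothing measured here explains this result.

All three numbers are high at a single tested concentration, so any difference in potency among these rings remains hidden. Still open, going by these compounds, is how this position would respond to something other than a plain carbon ring, such as an amine, a carboxylic acid or a longer open chain.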